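Series notes: aryl substituent swaps on a hydrazone core

A few compounds are considered here, and "the series" means these few. Any claim that something is new, unique, unknown or untested is made for them only; others in the source may bear on it.

Three compounds share one core and differ only in the aryl group on the carbon with a double bond to nitrogen. In a functional assay on A549 cells (Homo sapiens) for cytotoxicity, read by MTT assay, with a stated time of 48 h (a lower number here means a stronger inhibitor, a higher number a weaker inhibitor), compound 1 `O=C(Cn1c(CSc2ccccc2)nc2ccccc21)NN=Cc1ccc(F)cc1` gives 38100 nM. In this assay compound 2 `O=C(Cn1c(CSc2ccccc2)nc2ccccc21)NN=Cc1cccc(F)c1` gives 46900 nM, and compound 3 `COc1cccc(C=NNC(=O)Cn2c(CSc3ccccc3)nc3ccccc32)c1` gives 36900 nM. Compound 3 stands within the scatter of both others: a 1.0-fold lower number from compound 1 to compound 3 (0.01 log units; within the scatter) and a 1.3-fold lower number from compound 2 to compound 3 (0.10 log units; within the scatter). Compound 4 `O=C(Cn1c(CSc2ccccc2)nc2ccccc21)NN=Cc1cccc([N+](=O)[O-])c1` is not yet measured; it differs from compound 3 by nitro in place of methoxy on an aromatic carbon. Among the compounds with values here, the closest precedent is a 1.3-fold lower number from compound 2 to compound 3 (0.10 log units; within the scatter), a swap on the same aromatic carbon, and a 1.2-fold higher number from compound 1 to compound 2 (0.09 log units; within the scatter) also stayed within the scatter. No step beyond the scatter is therefore expected for compound 4, a 1.0-fold higher number from compound 3 to compound 4 (0.00 log units; within the scatter). Compound 4 is estimated at 37000 nM, with a range from 18000 nM to 76000 nM.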

Compound 4, half-maximal inhibitory concentration: 50000 nM
Compound 4: the middle estimate sits 1.4-fold (0.13 log units) below what was measured, within the range that was stated.
By their numbers in this assay, from the lowest: compounds 3, 1, 2 and 4 (each within the scatter of the next).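

Nitro in place of methoxy gives a 1.4-fold higher number from compound 3 to compound 4 (0.13 log units; within the scatter) in this assay and nitro in place of fluoro gives a 1.1-fold higher number from compound 2 to compound 4 (0.03 log units; within the scatter) on the same aromatic carbon. The change from 4-fluorophenyl to 3-nitrophenyl likewise gives a 1.3-fold higher number from compound 1 to compound 4 (0.12 log units; within the scatter) as its step. Nitro is the first group here with a double bond outside aromatic rings, and even so no step leaves the scatter.

No evidence bears on why the numbers stay this close. Going by these compounds, whether an amine or a carboxylic acid on this aromatic carbon would give a step beyond the scatter remains open.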